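A new group on the amide nitrogen of compound 1

A few compounds are considered here, and "the series" means these few. Any claim that something is new, unique, unknown or untested is made for them only; others in the source may bear on it.

In a functional assay on MIA PaCa-2 cells (Homo sapiens) for inhibition, read by MTT assay, with a stated time of 7 days (on this read-out higher numbers stand for weaker inhibition and lower numbers for stronger inhibition), compound 1 `CCN(CC)S(=O)(=O)c1ccc(S(=O)(=O)N2CCC[C@@H](C(=O)N[C@@H]3CCN(C(=O)OC(C)(C)C)C3)C2)cc1` gives 200 nM, while compound 2 `CCOC(=O)[C@@H]1C[C@@H](O)CN(S(=O)(=O)c2ccc(S(=O)(=O)N(CC)CC)cc2)C1` gives 7900 nM. Compound 1 therefore has the lower of the two numbers, meaning the stronger inhibition, and the gap lies beyond the usual scatter. Within the data shown here, these two compounds differ in more than one place, so the data offer no measured step for a single change.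

Compound 3 `CCN(CC)S(=O)(=O)c1ccc(S(=O)(=O)N2CCC[C@@H](C(=O)NC3CN(C(=O)NC(C)(C)C)C3)C2)cc1` has yet to be measured. Compared with compound 1, it carries 1-((tert-butyl)carbamoyl)azetidin-3-yl in place of 1-(tert-butoxycarbonyl)pyrrolidin-3-yl on an amide-type nitrogen, and the rest of the structure stays the same. Among the measured compounds shown here, no measured compound shows what this exchange does, so the expectation is only tentative. In this assay, a small rise in the number is expected, about the size of the scatter, which would mean slightly weaker inhibition. The expected step is a 2.0-fold higher number from compound 1 to compound 3 (0.30 log units; within the scatter). For compound 3 the estimated value is 400 nM, with an expected range of 100 nM to 1600 nM.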

Compound 3, half-maximal inhibitory concentration: 3400 nM
For compound 3 the middle estimate is 8.5-fold (0.93 log units) below the measured one; measured number above the stated range.
By their numbers in this assay, from the lowest: compound 1; then compound 3; then compound 2.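

Among these compounds, the first measured step at this place shows that inhibition in this assay is sensitive to the group on the amide-type nitrogen: replacing 1-(tert-butoxycarbonyl)pyrrolidin-3-yl with 1-((tert-butyl)carbamoyl)azetidin-3-yl gives a 17-fold higher number from compound 1 to compound 3 (1.23 log units; beyond the scatter), which means clearly weaker inhibition. This single exchange changes several features at once, as a five-membered ring gives way to a four-membered one, the tert-butoxycarbonyl group gives way to a (tert-butyl)carbamoyl group, a hydrogen-bond donor enters, and the defined stereocentre of the leaving group is lost. Nothing available here explains the loss of inhibition.

The compounds shown leave open which of these features accounts for the step, and the hybrids 1-(tert-butoxycarbonyl)azetidin-3-yl and 1-((tert-butyl)carbamoyl)pyrrolidin-3-yl would be the direct tests of ring and cap. On these data alone, it also remains open whether the tert-butyl-bearing cap is needed at all, a question that a free pyrrolidin-3-yl amine on the same amide-type nitrogen would address.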